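A Chlorophenyl Carbinol Replaces a Sulfanyl Arm

The source may hold more compounds than are shown below. What is called first, only, known or untested is meant among the compounds shown, and "the series" means these compounds.

In a functional assay on RAW264.7 cells (Mus musculus) for inhibition, with stated times of 2 h and 24 h (on this read-out higher numbers stand for weaker inhibition and lower numbers for stronger inhibition), compound 1 (`COc1ccc(/C=C2/c3cc(OC)cc(OC)c3[C@@H](c3ccc(OC)cc3)[C@@H]2c2cc(OC)cc(OC)c2)cc1`) gives 6260 nM. Compound 2 (`COc1ccc([C@@H]2c3c(OC)cc(OC)cc3/C(=C/c3ccc(Cl)cc3)[C@H]2c2cc(OC)cc(OC)c2)cc1`) gives > 200000 nM, which is a limit. Compound 3 (`COc1ccc([C@@H]2c3c(OC)cc(OC)cc3C(SCc3ccc(C)cc3)[C@H]2c2cc(OC)cc(OC)c2)cc1`) gives > 200000 nM, also a limit, and so stands at the limit of > 200000 nM in this assay, at which 2 of the 3 values shown sit. Compound 4 (`COc1ccc([C@@H]2c3c(OC)cc(OC)cc3C(C(O)c3ccc(Cl)cc3)[C@H]2c2cc(OC)cc(OC)c2)cc1`) has (4-chlorophenyl)(hydroxy)methyl in place of (4-methylbenzyl)sulfanyl on a saturated ring carbon. Within the data shown here, the only measured step, an at least 31-fold higher number from compound 1 to compound 2 (1.50 log units; beyond the scatter), is large and beyond the scatter, and it introduced chloro in place of methoxy on an aromatic carbon, so it offers no reason to expect a strong gain from the chlorine-bearing group in compound 4. Only a modest move towards stronger inhibition in this assay is expected, an estimated at least 1.6-fold lower number from compound 3 to compound 4 (0.22 log units; that floor lies within the scatter). For compound 4 the estimated value is 120000 nM, within a range of 30000 nM to 200000 nM.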

Compound 4, half-maximal inhibitory concentration: > 200000 nM
Compound 4 ended at the assay's limit (the forecaster's own chance of this, stated with the estimate: 60%); middle value at least 1.6-fold (0.22 log units) from the limit.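

Compound 3 and compound 4 both sit at the limit of this assay, so the step between them cannot be read: the limit of > 200000 nM in this assay, at which 3 of the 4 values shown sit.

On these data alone, whether (4-chlorophenyl)(hydroxy)methyl and (4-methylbenzyl)sulfanyl differ at all in inhibition remains open.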